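This account rests on a few compounds, and the source may have more. Where it says the series, first, only, none or still open, it means among the compounds named here.

Three compounds have been measured so far in a functional assay on cells (T-cell line, Homo sapiens) for inhibition; a lower number here means a stronger inhibitor, a higher number a weaker inhibitor:

- compound 1 `COc1ccc(CCCN2CCC(COCc3ccc(Cl)cc3)CC2)cc1` gives 500 nM
- compound 2 `COc1ccc(CCCN2CCC(COC(c3ccc(Br)cc3)c3ccc(Br)cc3)CC2)cc1` gives 3200 nM
- compound 3 `COc1ccc(CCCN2CCC(C(O)CC(c3ccccc3)c3ccccc3)CC2)cc1` gives 1500 nM

Compound 3 stands in the middle of these three in this assay, with a number lower than that of compound 2 and higher than that of compound 1. Both gaps lie beyond the scatter of repeated measurements.

Compound 4 `COc1ccc(CCCN2CCC(CCC(c3ccccc3)c3ccccc3)CC2)cc1` has not yet been measured. It differs from compound 3 in one place: hydrogen in place of hydroxy on a saturated chain carbon bound to a saturated chain carbon and a saturated ring carbon, with hydrogen in place of hydroxy on a saturated chain carbon bound to a saturated chain carbon and a saturated ring carbon.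

For the measured compounds named here, no two measured compounds differ in only one place, so nothing here shows this change directly. Compound 1 at 500 nM and compound 2 at 3200 nM also carry no hydroxy, yet they fall on either side of compound 3, so they set no firm direction. A small step towards a lower number is expected, and it may stay within the scatter. The estimated step is a 1.5-fold lower number from compound 3 to compound 4 (0.18 log units; within the scatter), and this is only a rough expectation. For compound 4 the expected value is 1000 nM, with an estimated range of 350 nM to 3000 nM.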

Compound 4, half-maximal inhibitory concentration: 200 nM
Compound 4: middle estimate off by 5.0-fold (0.70 log units), on the high side, and the stated range ends above it.
By their numbers in this assay, from the lowest: compound 4; then compound 1; then compound 3; then compound 2.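

In this assay, replacing the hydroxy with hydrogen on this saturated chain carbon, bound to a saturated chain carbon and a saturated ring carbon, gives a 7.5-fold lower number from compound 3 to compound 4 (0.88 log units; beyond the scatter), a step beyond the scatter. For the compounds shown here, this pair is the first direct view of this position, and it shows that inhibition here responds clearly to this one small change, with the hydroxy-bearing compound 3 the weaker inhibitor of the two. No measurement shown accounts for the size of this step.

This single pair leaves open whether the same change would have a similar effect on the other compounds with different groups on the shared core. It also leaves open how a methyl, a fluorine or an amine on this carbon would compare with hydrogen and hydroxy.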